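Pyridin-3-yl for benzyl on the piperazine nitrogen

A few compounds are considered here, and "the series" means these few. Any claim that something is new, unique, unknown or untested is made for them only; others in the source may bear on it.

Measured so far:
Compound 1, `Nc1ccccc1NC(=O)c1ccc(CSC(=S)N2CCN(C3CCCCC3)CC2)cc1`, gives 75.3% in a functional assay on MGC-803 cells (Homo sapiens) for antiproliferative activity, read by CCK-8 assay, with a stated time of 72 h, tested at 8 uM; a lower number here means a weaker effect, a higher number a stronger effect of the compound at the concentration tested.
Compound 2, `Nc1ccccc1NC(=O)c1ccc(CSC(=S)N2CCN(c3ccncc3)CC2)cc1`, gives 87.1% in this assay.
Compound 3, `Nc1ccccc1NC(=O)c1ccc(CSC(=S)N2CCN(Cc3ccccc3)CC2)cc1`, gives 19.7% in this assay.

Compound 3 stands lowest of the three; its nearest neighbour is compound 1 and the furthest is compound 2, both well beyond the scatter above it. Compound 4, `Nc1ccccc1NC(=O)c1ccc(CSC(=S)N2CCN(c3cccnc3)CC2)cc1`, differs from compound 3 in one place: pyridin-3-yl in place of benzyl on an amine nitrogen in a ring.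

For the measured compounds named here, two measured steps bear on this change, since both replace a group attached directly to the ring nitrogen by benzyl: a number 55.6 percentage points lower from compound 1 to compound 3 (beyond the scatter) and a number 67.4 percentage points lower from compound 2 to compound 3 (beyond the scatter). The pyridin-3-yl group entering in compound 4 shares with the pyridin-4-yl group of compound 2 the six-membered aromatic ring with one nitrogen bound directly to the ring nitrogen, so the step from compound 3 to compound 4 is expected to run in the opposite direction to those two steps and to be large, roughly undoing the loss seen from compound 2 to compound 3.

For compound 4 the expected value in this assay is therefore 76%, within a range from 48% to 92%, meaning an expected step of a number 56.3 percentage points higher from compound 3 to compound 4 (beyond the scatter).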

Compound 4, a percentage reported as inhibition, at one concentration (the size of the read-out at that concentration, not a potency): 76.9%
The estimate for compound 4 lay 0.9 percentage points below the measured number; measured number inside the range.
By their numbers in this assay, from the lowest: compound 3; then compounds 1 and 4 (each within the scatter of the next); then compound 2.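

In this assay, for the compounds shown here, pyridin-3-yl restores what benzyl lacks, with a number 57.2 percentage points higher from compound 3 to compound 4 (beyond the scatter), so the high values are not confined to pyridin-4-yl, and among the four compounds benzyl is the only group on this amine nitrogen that gives a low number. Going by these compounds alone, the two pyridine isomers can also be told apart here for the first time, with a number 10.2 percentage points lower from compound 2 to compound 4 (beyond the scatter), a modest step just beyond the scatter. An aromatic ring with a hetero atom is not required for this level of effect, since pyridin-3-yl and cyclohexyl cannot be separated, with a number 1.6 percentage points higher from compound 1 to compound 4 (within the scatter).

Nothing available explains these differences. Still open, as far as these compounds go, is whether a phenyl or pyridin-2-yl group on this nitrogen would match the pyridines, and whether a pyridin-3-ylmethyl group would fall to the level of benzyl.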